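The compounds below may be only part of what the source reports. "The series", "measured", "known", "first", "only" and "open" are said of these compounds alone.

Measured compounds in hand:
compound 1 `Cc1ncc([N+](=O)[O-])n1CCOc1ccccc1` — 107 ug/mL
compound 2 `Cc1ncc([N+](=O)[O-])n1CCOc1ccc(F)cc1` — 129 ug/mL

In a functional assay on A549 cells (Homo sapiens) for cytotoxicity, read by MTT assay, with a stated time of 24 h (a lower number here means a stronger inhibitor, a higher number a weaker inhibitor), compound 1 gives 107 ug/mL, and compound 2 gives 129 ug/mL. Compound 1 has the lowest of the two numbers, with compound 2 nearest to it, but a 1.2-fold higher number from compound 1 to compound 2 (0.08 log units; within the scatter) is within the scatter, so the two compounds cannot be told apart on this assay.

Compound 3 `Cc1ncc([N+](=O)[O-])n1CCOc1ccccc1Cl` has not yet been measured in this assay. It differs from compound 1 by chloro in place of hydrogen on an aromatic carbon.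

Among the measured compounds shown here, the only measured step that bears on this change is the one from compound 1 to compound 2, where fluoro replaced hydrogen on the same ring: a 1.2-fold higher number from compound 1 to compound 2 (0.08 log units; within the scatter). That step lies within the scatter. Chloro enters at a different place on the ring than fluoro did, so the comparison is loose, but nothing in the series so far shows a step beyond the scatter for a single substitution on this ring. The expectation for compound 3 is therefore a step of a 1.0-fold higher number from compound 1 to compound 3 (0.01 log units; within the scatter), no direction claimed beyond the scatter. Compound 3 is estimated at 110 ug/mL, with a range from 55 ug/mL to 220 ug/mL.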

Compound 3, half-maximal inhibitory concentration: 574 ug/mL
Beside the measured number, compound 3's estimate is 5.2-fold (0.72 log units) below it; measured number outside the range, above it.
By their numbers in this assay, from the lowest: compounds 1 and 2 (each within the scatter of the next); then compound 3.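

The chloro group, ortho to a large group, brings a 5.4-fold higher number from compound 1 to compound 3 (0.73 log units; beyond the scatter) in this assay and is the only single substitution shown whose step on this ring lies beyond the scatter, here toward a weaker inhibitor. Fluoro gave a 1.2-fold higher number from compound 1 to compound 2 (0.08 log units; within the scatter) in the same assay, so the earlier picture of a ring on which single substitutions leave the number within the scatter does not hold for every group and place. No measurement shown bears on why the chloro step is larger than the fluoro step.

On these data alone, the two steps differ in both the group that enters and where it sits, so it remains open whether the step from compound 1 to compound 3 follows chloro itself or the place ortho to a large group. The answer would come from fluoro at that place and from chloro at the place fluoro holds in compound 2, while a methoxy group or an amine at the same place would show whether other groups give a step of similar size.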